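Working notes: changing the sulfonyl substituent of compound 2

The source may hold more compounds than are shown below. What is called first, only, known or untested is meant among the compounds shown, and "the series" means these compounds.

Measured so far in a physicochemical assay for solubility, in phosphate buffer, with a stated time of 24 h, at pH 7.4, tested at 100 uM; a higher number here means a more soluble compound, a lower number a less soluble compound:
- Compound 1 `O=S(=O)(c1ccccc1)c1ccc(CNS(=O)(=O)N2Cc3ccncc3C2)cc1` gives 3000 nM here
- Compound 2 `O=C(NCc1ccc(S(=O)(=O)c2cc(F)cc(F)c2)cc1)N1Cc2ccncc2C1` gives 16000 nM here

Compound 2 stands highest of the two, with compound 1 lower by more than the scatter. Compound 3 `O=C(NCc1ccc(S(=O)(=O)C2CCC(F)(F)CC2)cc1)N1Cc2ccncc2C1` carries 4,4-difluorocyclohexyl in place of 3,5-difluorophenyl on a sulfonyl sulfur. Going by the values given here, no measured pair shows this change, so the expectation rests only on compound 2 (16000 nM) and the structural change. The expected step (a 1.6-fold higher number from compound 2 to compound 3 (0.19 log units; within the scatter)) is upward but stays within the scatter. For compound 3 the estimated value is 25000 nM (expected range 8000 nM to 80000 nM).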

Compound 3, solubility: 35000 nM
The estimate for compound 3 lay 1.4-fold (0.15 log units) below the measured number, and the stated range covers the measured number.
By their numbers in this assay, from the lowest: compound 1; then compound 2; then compound 3.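

Working from the sulfonyl sulfur, 4,4-difluorocyclohexyl in place of 3,5-difluorophenyl gives a 2.2-fold higher number from compound 2 to compound 3 (0.34 log units; beyond the scatter) in this assay and is the first single-place comparison in the series. The ring at this position goes from aromatic to non-aromatic while the carbon and fluorine content of the group stays unchanged, so the number here responds to that exchange alone. No supporting data bear on the reason for this step.

Still open, going by these compounds, is how an unsubstituted cyclohexyl, or a ring carrying an amine or a carboxylic acid, would read at this sulfonyl sulfur.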